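Replacing the Isobutyl Ketone with a Difluorophenyl Ketone

The source may hold more compounds than are shown below. What is called first, only, known or untested is meant among the compounds shown, and "the series" means these compounds.

Compound 1 `CCOC(=O)N1CCN(CCCOc2ccc(C(C)=O)cc2)CC1`: 39800 nM
Compound 2 `CCCCCCCCC(=O)c1ccc(OCCCN2CCN(C(=O)OCC)CC2)cc1`: 2690 nM
Compound 3 `CCOC(=O)N1CCN(CCCOc2ccc(C(=O)CC(C)C)cc2)CC1`: 69200 nM

All three share one core and differ only in the group on the ketone carbonyl. In an assay on isolated protein for binding affinity to histamine H2 receptor (Homo sapiens) (on this read-out lower numbers stand for stronger inhibition and higher numbers for weaker inhibition), compound 3 stands highest of the three. a 1.7-fold higher number from compound 1 to compound 3 (0.24 log units; within the scatter), and a 26-fold higher number from compound 2 to compound 3 (1.41 log units; beyond the scatter). Compound 4 `CCOC(=O)N1CCN(CCCOc2ccc(C(=O)c3cccc(F)c3F)cc2)CC1` carries 2,3-difluorophenyl in place of isobutyl on a carbonyl carbon. Among the compounds with values here, no measured step swaps an alkyl group for an aromatic ring, so the alkyl steps are the only guide: a 15-fold lower number from compound 1 to compound 2 (1.17 log units; beyond the scatter) was large, whereas a 1.7-fold higher number from compound 1 to compound 3 (0.24 log units; within the scatter) stayed within the scatter. A larger group has once lowered the number strongly and once not at all, so a moderate lowering is expected, a 3.5-fold lower number from compound 3 to compound 4 (0.54 log units; beyond the scatter). Compound 4 is therefore estimated at 20000 nM, within 3000 nM to 100000 nM.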

Compound 4, inhibition constant: 17400 nM
Compound 4: middle estimate off by 1.1-fold (0.06 log units), on the high side; the measured number falls inside the stated range.
By their numbers in this assay, from the lowest: compound 2; then compound 4; then compounds 1 and 3 (each within the scatter of the next).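

An aromatic ring on the carbonyl carbon works at this position: 2,3-difluorophenyl gives a lower number than isobutyl (a 4.0-fold lower number from compound 3 to compound 4 (0.60 log units; beyond the scatter)) and than methyl (a 2.3-fold lower number from compound 1 to compound 4 (0.36 log units; beyond the scatter)), both modest steps. Even so, it does not match the octyl group of compound 2 (a 6.5-fold higher number from compound 2 to compound 4 (0.81 log units; beyond the scatter)). No available evidence explains these differences. On these data alone, whether the two fluorines contribute stays open, and a plain phenyl ketone would be the direct comparison. Also open, as far as these compounds go, is whether a pyridyl ring or a chain longer than octyl would lower the number further.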